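From compound 2 to compound 4: a methoxyphenyl swap

This account rests on a few compounds, and the source may have more. Where it says the series, first, only, none or still open, it means among the compounds named here.

Of the compounds shown here, three sharing one core have been measured in a functional assay on MCF7 cells (Homo sapiens) for cytotoxicity; on this read-out lower numbers stand for stronger inhibition and higher numbers for weaker inhibition. There, compound 1 `C=C/C=C\[C@H](C)[C@H](OC(N)=O)[C@@H](C)[C@H](O)[C@@H](C)C/C(C)=C\[C@H](C)[C@@H](O)[C@@H](C)/C=C\CCc1ccc(Oc2ccccc2)cc1` gives 4000 nM, compound 2 `C=C/C=C\[C@H](C)[C@H](OC(N)=O)[C@@H](C)[C@H](O)[C@@H](C)C/C(C)=C\[C@H](C)[C@@H](O)[C@@H](C)/C=C\CCc1ccc(C)c(O)c1` gives 770 nM and compound 3 `C=C/C=C\[C@H](C)[C@H](OC(N)=O)[C@@H](C)[C@H](O)[C@@H](C)C/C(C)=C\[C@H](C)[C@@H](O)[C@@H](C)/C=C\CCc1ccccc1` gives 480 nM. Compound 2 thus stands within the scatter of compound 3, while compound 1 stands apart with the highest number.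

Compound 4 `C=C/C=C\[C@H](C)[C@H](OC(N)=O)[C@@H](C)[C@H](O)[C@@H](C)C/C(C)=C\[C@H](C)[C@@H](O)[C@@H](C)/C=C\CCc1cccc(OC)c1` has not yet been measured. It carries 3-methoxyphenyl in place of 3-hydroxy-4-methylphenyl on a saturated chain carbon, two bonds along the chain from a double-bonded chain carbon.

Going by the values given here, two measured steps bear on this change. The step of a 1.6-fold lower number from compound 2 to compound 3 (0.21 log units; within the scatter) replaces the same 3-hydroxy-4-methylphenyl with plain phenyl and stays within the scatter. The step of an 8.3-fold lower number from compound 1 to compound 3 (0.92 log units; beyond the scatter) goes beyond the scatter, but it concerns phenoxy, which compound 4 does not carry. No step beyond the scatter is therefore expected in this assay. The expected change is a 1.1-fold lower number from compound 2 to compound 4 (0.04 log units; within the scatter). For compound 4 the estimated value is 700 nM, with an expected range of 300 nM to 1800 nM.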

Compound 4, half-maximal inhibitory concentration: 330 nM
For compound 4 the middle estimate is 2.1-fold (0.33 log units) above the measured one, and the stated range covers the measured number.
By their numbers in this assay, from the lowest: compounds 4, 3 and 2 (each within the scatter of the next, the first and the last beyond it); then compound 1.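

In this assay, the step to 3-methoxyphenyl gives a 2.3-fold lower number from compound 2 to compound 4 (0.37 log units; beyond the scatter) and so passes beyond the scatter, a modest change that the swap to plain phenyl did not reach. Methoxy in place of hydrogen on the ring gives a 1.5-fold lower number from compound 3 to compound 4 (0.16 log units; within the scatter) and stays within the scatter, so at this place on the chain the ring accepts this oxygen-bearing group with no hydrogen-bond donor and the number holds at the level of plain phenyl. Nothing available here accounts for the step from 3-hydroxy-4-methylphenyl to 3-methoxyphenyl.

The compounds shown do not separate the loss of the hydroxy from the loss of the methyl within that step. As far as these compounds go, whether a ring bearing ethoxy, fluorine or a dimethylamino group would hold this level remains open.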